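Swapping a dimethylphenyl amide for a pyrimidinyl amide

The compounds below may be only part of what the source reports. "The series", "measured", "known", "first", "only" and "open" are said of these compounds alone.

Measured so far:
- compound 1 `COc1ccc2nc(C)cc(OCC(=O)Nc3cc(C)cc(C)c3)c2c1`: 26000 nM
- compound 2 `COc1ccc2nc(C)cc(OCC(=O)Nc3cc(C)c(OC)c(C)c3)c2c1`: 17000 nM

In a physicochemical assay for solubility, in phosphate buffer, measured as kinetic solubility, with a stated time of 1 h, at pH 7.4 (a lower number here means a less soluble compound, a higher number a more soluble compound), compound 1 gives 26000 nM, the highest of the two numbers, and its nearest neighbour compound 2 gives 17000 nM. Within the data shown here, the one measured step, a 1.5-fold lower number from compound 1 to compound 2 (0.18 log units; within the scatter), lies within the scatter, so the two values show no real difference.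

Compound 3 `COc1ccc2nc(C)cc(OCC(=O)Nc3ccncn3)c2c1` differs from compound 1 in this way: pyrimidin-4-yl in place of 3,5-dimethylphenyl on an amide-type nitrogen. Among the measured compounds shown here, no measured step concerns this kind of change; the step from compound 1 to compound 2 touches a different part of the molecule and, being within the scatter, gives no direction. The expectation therefore rests on the structural change alone, and it is expected to move solubility upward: a 2.3-fold higher number from compound 1 to compound 3 (0.36 log units; beyond the scatter). Compound 3 is estimated to give 60000 nM in this assay, with a likely range from 20000 nM to 180000 nM.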

Compound 3, solubility: 27500 nM
For compound 3 the middle estimate is 2.2-fold (0.34 log units) above the measured one, within the range that was stated.
By their numbers in this assay, from the lowest: compounds 2, 1 and 3 (each within the scatter of the next).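

In this assay the swap of 3,5-dimethylphenyl for pyrimidin-4-yl on the amide-type nitrogen gives a 1.1-fold higher number from compound 1 to compound 3 (0.02 log units; within the scatter) and so leaves compound 1 and compound 3 indistinguishable. Compound 2 only added a methoxy to the aromatic ring, whereas this change replaces the whole ring, and an all-carbon ring without hydrogen-bond acceptors gives way to one with 2 hetero atoms and 2 hydrogen-bond acceptors. Even this large change in structure yields no difference beyond the scatter, and no measurement shown offers a reason for that result.

The compounds shown leave open whether a different group on this nitrogen, such as a pyridinyl ring or a phenyl ring carrying an amine or a carboxylic acid, would give a number beyond the scatter. They also leave open whether pyrimidin-4-yl would give the same result on a core other than the one shared here.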